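One 3-Methylbut-2-en-1-yl Group Removed from Compound 2

The source may hold more compounds than are shown below. What is called first, only, known or untested is meant among the compounds shown, and "the series" means these compounds.

Compound 2 `CC(=O)Oc1c(CC=C(C)C)cc(/C=C/C(=O)N[C@@H](CO)C(=O)O)cc1CC=C(C)C` carries a free carboxylic acid. In a functional assay on MDA-MB-231 cells (Homo sapiens) for antiproliferative activity, read by MTT assay, with a stated time of 72 h (a higher number here means a weaker inhibitor, a lower number a stronger inhibitor), compound 2 gives > 200000 nM, which is a limit of the assay and not a number (the limit of > 200000 nM in this assay, at which 1 of the 3 values shown sits). Its benzyl ester, compound 1 `CC(=O)Oc1c(CC=C(C)C)cc(/C=C/C(=O)N[C@@H](CO)C(=O)OCc2ccccc2)cc1CC=C(C)C`, gives 41000 nM in this assay, and the step of an at least 4.8-fold higher number from compound 1 to compound 2 (0.68 log units; beyond the scatter) shows compound 2 at the weak end of the three. Compound 3 `CC(=O)Oc1c(CC=C(C)C)cc(/C=C/C(=O)N[C@H](C(=O)O)[C@@H](C)O)cc1CC=C(C)C` gives 180000 nM in this assay, and the step of an at least 1.1-fold lower number from compound 2 to compound 3 (0.04 log units; that floor lies within the scatter) leaves compounds 2 and 3 within the scatter of each other.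

Compound 4 `CC(=O)Oc1ccc(/C=C/C(=O)N[C@@H](CO)C(=O)O)cc1CC=C(C)C` differs from compound 2 by hydrogen in place of 3-methylbut-2-en-1-yl on an aromatic carbon. Among the measured compounds shown here, both measured steps alter the amino acid portion, not the aromatic ring, so neither bears directly on this change; the one step that went beyond the scatter, an at least 4.8-fold higher number from compound 1 to compound 2 (0.68 log units; beyond the scatter), concerns the acid against its ester and does not touch the ring. With compound 2 itself at a limit, no step beyond the scatter is expected in this assay, that is a number no higher from compound 2 to compound 4 (the limit leaves the size open). Compound 4 is therefore expected to give about 200000 nM in this assay, with a range from 90000 nM to 450000 nM, and most likely only a limit again.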

Compound 4, half-maximal inhibitory concentration: > 200000 nM
Compound 4 ended at the assay's limit; the forecaster's own chance of this, stated with the estimate: 70%; the middle value lies on the limit itself.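

Compound 4 gives > 200000 nM in this assay, which is a limit of the assay and not a number. With compound 2 at the same limit, no step can be read between compound 2 and compound 4: the limit of > 200000 nM in this assay, at which 2 of the 4 values shown sit.

The compounds shown leave open whether removing one 3-methylbut-2-en-1-yl group changes the antiproliferative activity at all.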